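Changing the ring on nitrogen: what to expect for compound 4

This account rests on a few compounds, and the source may have more. Where it says the series, first, only, none or still open, it means among the compounds named here.

Measured so far in an assay on Sf9 cells for inhibition of protein deacetylase HDAC6 (Homo sapiens), read by fluorescence, with a stated time of 40 min, tested at 100 nM; on this read-out lower numbers stand for less inhibition and higher numbers for more inhibition at the one concentration tested (going by the name of the read-out):
compound 1 `O=C(NO)c1ccc(NCc2nc(-c3ccccc3)nn2-c2cccc(Cl)c2)cc1` gives 62.3%
compound 2 `Cc1ccccc1-c1nc(CNc2ccc(C(=O)NO)cc2)n(-c2ccccc2)n1` gives 53.2%
compound 3 `O=C(NO)c1ccc(NCc2nc(-c3ccc(F)cc3)nn2-c2ccccc2)cc1` gives 70.9%

Among these three numbers compound 1 stands second highest. Its nearest neighbour is compound 3, which lies higher, but within the scatter of repeated measurements; compound 2 lies lower, also within the scatter. Compound 1 is therefore not set apart from either of the other two on the numbers shown.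

Compound 4 `Cc1ccc(-n2nc(-c3ccccc3)nc2CNc2ccc(C(=O)NO)cc2)cc1C` is the next to be measured in this assay. It differs from compound 1 in one place: 3,4-dimethylphenyl in place of 3-chlorophenyl on an aromatic nitrogen. The group that enters and the group that leaves are both single six-membered aromatic rings of carbon only, with no hydrogen-bond donors or acceptors.

Within the data shown here, the one measured step, a number 17.7 percentage points higher from compound 2 to compound 3 (beyond the scatter), changes a group on an aromatic carbon, not on the aromatic nitrogen, so it does not bear on this change. Nothing measured shows how a change of the ring on the aromatic nitrogen moves the read-out. The expectation is therefore no step beyond the scatter, a number 2.3 percentage points lower from compound 1 to compound 4 (within the scatter). The estimate for compound 4 is 60%, with a range from 40% to 78%.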

Compound 4, a percentage reported as inhibition, at one concentration (the size of the read-out at that concentration, not a potency): 53%
The estimate for compound 4 lay 7 percentage points above the measured number; the measured number falls inside the stated range.
By their numbers in this assay, from the lowest: compounds 4, 2, 1 and 3 (each within the scatter of the next, the first and the last beyond it).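

Among these compounds, this is the first measured change of the ring on the aromatic nitrogen of the shared core: in this assay the swap of 3-chlorophenyl for 3,4-dimethylphenyl gives a number 9.3 percentage points lower from compound 1 to compound 4 (within the scatter) and so stays inside the usual spread of repeats. At this position, then, the ring can lose its chlorine and gain two methyl groups without a step that can be told apart from that spread. Nothing available here explains the size of this step.

Both rings at this position carry only chlorine or methyl groups, so the compounds shown leave open how the read-out would respond to an amine or a carboxylic acid on that ring. A longer chain in place of the ring on the aromatic nitrogen also remains an open question.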